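Adding a Hydroxy Group Where Every Analogue Sits at the Limit

The source may hold more compounds than are shown below. What is called first, only, known or untested is meant among the compounds shown, and "the series" means these compounds.

Of the compounds shown here, three have been tested in a functional assay on HT-29 cells (Homo sapiens) for cytotoxicity, read by MTT assay, with a stated time of 48 h; a higher number here means a weaker inhibitor, a lower number a stronger inhibitor. Compound 1 `COC(=O)c1c(CCc2ccccc2)cc2c(c1O)CC(O)C(C)(C)O2` gives only a limit of the assay, > 40000 nM. Compound 2 `O=C1C=Cc2c(O)cc(CCc3ccccc3O)cc2OC1` likewise gives only a limit, > 40000 nM. Compound 3 `CC1=CCc2c(O)cc(CCc3ccccc3)cc2OC1` also gives only a limit, > 40000 nM. Compound 3 thus stands together with the other two at the limit of > 40000 nM in this assay, at which 3 of the 3 values shown sit, and no order among them can be drawn. Compound 4 `CC1=CCc2c(O)cc(CCc3ccccc3O)cc2OC1` differs from compound 3 by hydroxy in place of hydrogen on an aromatic carbon, and the same 2-hydroxyphenyl is already present in compound 2. Because compound 2 already gives the limit > 40000 nM in this assay, no step beyond the scatter is expected. The step that the limit leaves unreadable from compound 3 to compound 4 is expected to be within the scatter. Compound 4 is therefore estimated at 60000 nM, within 20000 nM to 200000 nM, most likely reported again only as a limit.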

Compound 4, half-maximal inhibitory concentration: 24300 nM
For compound 4 the middle estimate is 2.5-fold (0.39 log units) above the measured one; low and high end bracket the measured number.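

In this assay, compound 4 is the only compound shown that gives a number rather than a limit, so this position on the phenyl ring can now be read at least in part. Hydroxy in place of hydrogen on an aromatic carbon gives an at least 1.6-fold lower number from compound 3 to compound 4 (0.21 log units; that floor lies within the scatter), and this floor is all that can be said of the step, as the remaining values stay a limit: the limit of > 40000 nM in this assay, at which 3 of the 4 values shown sit.

From the compounds shown here alone, the true size of the step remains open. So does whether methoxy, an amine or a carboxylic acid at this position would give a number in this assay.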